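Heptyl to dodecyl on the epimeric core: working notes

The source may report more compounds than this note shows. Statements on the series, on what has been measured and on what is new or still open speak of the compounds shown alone.

Measured in a functional assay on EC9706 cells (Homo sapiens) for antiproliferative activity, read by MTT assay, with a stated time of 48 h (a lower number here means a stronger inhibitor, a higher number a weaker inhibitor), so far:
- compound 1 `CCCCCCCn1cc(COC[C@@H]2OC[C@H](N)[C@@H]2O)nn1` gives > 128000 nM as a limit
- compound 2 `CCCCCCCCCn1cc(COC[C@@H]2OC[C@H](N)[C@@H]2O)nn1` gives 20100 nM as a number
- compound 3 `CCCCCCCn1cc(COC[C@@H]2OC[C@H](N)[C@H]2O)nn1` gives > 128000 nM as a limit

Compound 3 stands at the limit of > 128000 nM in this assay, at which 2 of the 3 values shown sit, and offers no number to start from. Compound 4 `CCCCCCCCCCCCn1cc(COC[C@@H]2OC[C@H](N)[C@H]2O)nn1` brings one change (pentyl in place of hydrogen on a saturated chain carbon, seven bonds along the chain from an aromatic nitrogen) on the chain of compound 3. Among the compounds with values here, the one readable guide is compound 2 (an at least 6.3-fold lower number from compound 1 to compound 2 (0.80 log units; beyond the scatter)) where ethyl replaces hydrogen at that same place. From the compounds shown here alone, the other step stays open (a step that the two limits leave unreadable from compound 1 to compound 3) despite the fact that compounds 1 and 3 differ only in the configuration as drawn and so gives no guidance. A single step is thin support, but a lower number is expected again. The expected step is an at least 10-fold lower number from compound 3 to compound 4 (1.02 log units; beyond the scatter) in this assay as a move to a lower number. Compound 4 is estimated at 12000 nM with an expected range from 3000 nM to 60000 nM for now.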

Compound 4, half-maximal inhibitory concentration: 93800 nM
The estimate for compound 4 lay 7.8-fold (0.89 log units) below the measured number; measured number above the stated range.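

In this assay, pentyl in place of hydrogen on this chain carbon gives an at least 1.3-fold lower number from compound 3 to compound 4 (0.13 log units; that floor lies within the scatter), so the epimeric core now yields a readable number, but no step beyond the scatter is established. The step remains only a floor because its starting value for compound 3 is a limit: the limit of > 128000 nM in this assay, at which 2 of the 4 values shown sit. The step between the two configurations cannot be read.

Still open, from the compounds shown here alone, is how dodecyl would read on the core of compound 1. Also open, going by these compounds, is how a carboxylic acid in place of pentyl would read on the core of compound 4.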